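Series notes: acidic heterocycle in place of the primary amide

The compounds below may be only part of what the source reports. "The series", "measured", "known", "first", "only" and "open" are said of these compounds alone.

Compound 3 `CC(C)C(CC(N)=O)c1ccc(-c2ccc3cccc(F)c3c2)[nH]c1=O` carries a carbamoylmethyl group on the shared core. In an ADME assay on microsomes from liver (Homo sapiens) for metabolic stability (a higher number here means that the compound lasts longer, a lower number that the compound disappears faster), compound 3 gives < 0.0667 h, which is a limit of the assay and not a number. Compound 1 `CC(C)C(c1ccc(-c2ccc3cccc(F)c3c2)[nH]c1=O)N1CCNC1=O` gives 1.03 h in this assay. Compound 2 `CC(C)C(Cc1nnn[nH]1)c1ccc(-c2ccc3cccc(F)c3c2)[nH]c1=O` gives > 3 h in this assay, again a limit rather than a number. The steps run an at least 15-fold lower number from compound 1 to compound 3 (1.18 log units; beyond the scatter) and an at least 44-fold lower number from compound 2 to compound 3 (1.65 log units; beyond the scatter); both are only bounds, because the limit of < 0.0667 h in this assay, at which 1 of the 3 values shown sits, and the limit of > 3 h in this assay, at which 1 of the 3 values shown sits, cap what can be read.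

Compound 4 `CC(C)C(Cc1noc(=O)[nH]1)c1ccc(-c2ccc3cccc(F)c3c2)[nH]c1=O` differs from compound 3 by a group of 6 heavy atoms (2 carbon, 2 nitrogen, 2 oxygen; one five-membered aromatic ring with 3 hetero atoms) in place of a group of 3 heavy atoms (1 carbon, 1 nitrogen, 1 oxygen; no ring), on a saturated chain carbon, two bonds along the chain from an aromatic carbon. The step that bears on it is the reverse of the move from compound 2 to compound 3, where a five-membered aromatic ring with hetero atoms was replaced by carbamoyl and the number fell by an at least 44-fold lower number from compound 2 to compound 3 (1.65 log units; beyond the scatter). Restoring a five-membered aromatic ring with hetero atoms in compound 4 is therefore expected to give a large rise, an at least 22-fold higher number from compound 3 to compound 4 (1.35 log units; beyond the scatter), with the ring in compound 2 as the only precedent. Compound 4 is estimated at 1.5 h, within 0.3 h to 3 h.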

Compound 4, half-life: > 3 h
Compound 4: no number, only a limit; the forecaster's own chance of this, stated with the estimate: 35%; middle value at least 2.0-fold (0.30 log units) away from the limit.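

At this place, on a saturated chain carbon, two bonds along the chain from an aromatic carbon, a second five-membered aromatic ring in place of carbamoyl gives an at least 44-fold higher number from compound 3 to compound 4 (1.65 log units; beyond the scatter). Set against the 2-oxoimidazolidin-1-yl group, the same ring gives an at least 2.9-fold higher number from compound 1 to compound 4 (0.46 log units; beyond the scatter), so the rise over compound 1 and compound 3 no longer rests on the 1H-tetrazol-5-yl group of compound 2 alone. In this assay compound 4 gives > 3 h, a limit of the assay and not a number, and what can be read of its steps ends there: the limit of > 3 h in this assay, at which 2 of the 4 values shown sit.

On these data alone, the step between compound 2 and compound 4 cannot be read, and the order of the two rings stays open. Also open, as far as these compounds go, is how a carboxylic acid on the same chain carbon, or a longer chain carrying the 1H-tetrazol-5-yl group, would compare.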